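The compounds below may be only part of what the source reports. "The series", "measured", "known", "first", "only" and "open" are said of these compounds alone.

Going by the values given here, in a functional assay on Gurav cells (Homo sapiens) for inhibition, read by sulforhodamine B assay (on this read-out lower numbers stand for stronger inhibition of growth and higher numbers for weaker inhibition of growth), two compounds have numbers so far. Compound 1 (`Cc1ccc2[nH]c(-c3ccc(-c4ccc(-c5cccc(Cl)c5)cc4)cc3)nc2c1`) gives 2120 nM as its concentration for half growth inhibition. Compound 2 (`COc1ccc(-c2ccc(-c3ccc(-c4nc5ccccc5[nH]4)cc3)cc2)cc1`) gives 38100 nM and holds the higher of the two numbers, beyond the scatter from compound 1. Compound 3 (`Clc1cccc(-c2ccc(-c3ccc(-c4nc5ccccc5[nH]4)cc3)cc2)c1`) is still unmeasured. It has 3-chlorophenyl in place of the 4-methoxyphenyl of compound 2 on an aromatic carbon (3-chlorophenyl in place of 4-methoxyphenyl on an aromatic carbon). Among the compounds with values here, no measured pair isolates this change. The nearest guide is compound 1, which also carries 3-chlorophenyl and gives 2120 nM on a core that differs from that of compound 3. In this assay the expected step is a fall beyond the scatter (a 13-fold lower number from compound 2 to compound 3 (1.10 log units; beyond the scatter)) to a number near that of compound 1. Compound 3 is estimated at 3000 nM within an expected range of 1000 nM to 10000 nM in this measurement.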

Compound 3, concentration for 50% growth inhibition: 2190 nM
The estimate for compound 3 lay 1.4-fold (0.14 log units) above the measured number, within the range that was stated.
By their numbers in this assay, from the lowest: compounds 1 and 3 (each within the scatter of the next); then compound 2.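

In this assay, replacing 4-methoxyphenyl with 3-chlorophenyl on this aromatic carbon, para to a large group, gives a 17-fold lower number from compound 2 to compound 3 (1.24 log units; beyond the scatter), the first measured size for this change. With 3-chlorophenyl in place, hydrogen in place of methyl on an aromatic carbon gives a 1.0-fold higher number from compound 1 to compound 3 (0.01 log units; within the scatter), so this methyl makes no difference that can be read beyond the scatter. Nothing on hand accounts for either step.

The 2>3 change alters both the substituent and where it sits on the ring, and the compounds shown do not separate these two parts. On these data alone, how a phenyl ring carrying an amine or a carboxylic acid would read at this position also remains open.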